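Hydroxy for chloro across two cores

The compounds below may be only part of what the source reports. "The series", "measured", "known", "first", "only" and "open" are said of these compounds alone.

Measured compounds:
compound 1 `N#Cc1c(-c2ccc(Cl)cc2)nc(SCC(=O)Nn2c(COc3ccc(Cl)cc3Cl)nc3ccccc3c2=O)n(Cc2ccccc2)c1=O`: 77.2%
compound 2 `N#Cc1c(-c2ccc(O)cc2)nc(SCC(=O)Nn2c(COc3ccc(Cl)cc3Cl)nc3ccccc3c2=O)n(Cc2ccccc2)c1=O`: 56.1%
compound 3 `N#Cc1c(Nc2ccc(Cl)cc2)nc(SCC(=O)Nn2c(COc3ccc(Cl)cc3Cl)nc3ccccc3c2=O)nc1-c1ccc(Cl)cc1`: 61.4%

All three were measured in a functional assay on the whole organism (strain albino) for inhibition, with Rattus norvegicus as the target, read by paw edema, with stated times of 1 h and 2 h, at a dose of 100 mg/kg by the oral route; a lower number here means less inhibition, a higher number more inhibition at the dose given (going by the name of the read-out). Compound 1 and compound 2 share one core; compound 3 carries a different core, and the difference between the two cores is not broken down here. Within the first core the single change hydroxy in place of chloro on an aromatic carbon gave the step of a number 21.1 percentage points lower from compound 1 to compound 2 (beyond the scatter).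

Compound 3 is the untouched parent of the second core. In this assay compound 3 sits second of the three numbers: its value lies within the scatter of compound 2 and beyond the scatter of compound 1.

Compound 4 `N#Cc1c(Nc2ccc(O)cc2)nc(SCC(=O)Nn2c(COc3ccc(Cl)cc3Cl)nc3ccccc3c2=O)nc1-c1ccc(Cl)cc1` is not yet measured. It is obtained from compound 3 by hydroxy in place of chloro on an aromatic carbon, the same change as that between compound 1 and compound 2, at a place described in the same words.

Going by the values given here, since only one earlier instance of this change exists, the expectation rests on a single step. Compound 4 is expected to follow it, estimated at 42%, between 28% and 56%, because compound 1 to compound 2 gave a number 21.1 percentage points lower from compound 1 to compound 2 (beyond the scatter). The step this implies from compound 3 is estimated at a number 19.4 percentage points lower from compound 3 to compound 4 (beyond the scatter). Whether the second core carries the change the same way remains to be seen from the measurement.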

Compound 4, a percentage reported as inhibition, in the whole organism at one dose (the size of the read-out at that dose, not a potency): 91.2%
Compound 4: middle estimate off by 49.2 percentage points, on the low side; measured number above the stated range.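

In this assay, hydroxy in place of chloro on an aromatic carbon gave a number 29.8 percentage points higher from compound 3 to compound 4 (beyond the scatter), so on this second core the change raises the inhibition read-out, whereas on the first core it lowered it. A step measured on one core therefore did not predict either the direction or the size of the step on the other core in this series, as the two steps set side by side make plain: the same change on two cores in this assay, a number 21.1 percentage points lower (beyond the scatter) from compound 1 to compound 2 and a number 29.8 percentage points higher (beyond the scatter) from compound 3 to compound 4, 50.9 percentage points apart, beyond the scatter of two such steps. Going by these compounds alone, this does not show what sets the two cores apart, since only two pairs are at hand, the core difference is not broken down, the change sits on a 4-chlorophenyl group in one pair and on a (4-chlorophenyl)amino group in the other, and each figure is a reading at one dose rather than a potency.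

Open, on these data alone, is whether the rise on the second core belongs to hydroxy itself, or whether a methoxy group, an amine or a carboxylic acid at the same place on the (4-chlorophenyl)amino group would give a similar reading. Also open, as far as these compounds go, is how the 4-chlorophenyl group that compound 3 and compound 4 both retain would respond to the same change.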